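The compounds below may be only part of what the source reports. "The series", "measured", "known", "first", "only" and "open" are said of these compounds alone.

In an assay on isolated protein for inhibition of 2-Hydroxyacid oxidase 1 (Homo sapiens), with stated times of 30 min and 15 min (on this read-out higher numbers stand for weaker inhibition and lower numbers for stronger inhibition), three compounds with a shared core have been measured. Compound 1 `CC(C)c1noc(-c2cccc(CNc3ccc4[nH]nc(C(=O)O)c4c3)c2O)n1` gives 47 nM in this assay. Compound 2 `CC(C)c1csc(-c2cccc(CN(C)c3ccc4[nH]nc(C(=O)O)c4c3)c2O)n1` gives 35 nM. Compound 3 `Cc1nc(-c2cccc(CNc3ccc4[nH]nc(C(=O)O)c4c3)c2O)sc1C` gives 25 nM, which sits at the low end of the three numbers; the step of a 1.9-fold lower number from compound 1 to compound 3 (0.27 log units; within the scatter) is within the scatter, and the gap between compound 3 and compound 2 is within the scatter as well, so the three stand on a level.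

Compound 4 `Cc1csc(-c2cccc(CNc3ccc4[nH]nc(C(=O)O)c4c3)c2O)n1` is compound 3 with one change: hydrogen in place of methyl on an aromatic carbon. Among the measured compounds shown here, no measured step in this set removes a single methyl from the five-membered ring; the only step available, from compound 1 to compound 3, exchanges the whole ring and still stays within the scatter. For the measured compounds named here, the one methyl leaving in compound 4 is a smaller change than that exchange, and nothing among the measured compounds points to a direction for it. Compound 4 is therefore expected to give a number close to that of compound 3, with the expected step of a 1.4-fold higher number from compound 3 to compound 4 (0.15 log units; within the scatter) not beyond the scatter. The estimate for compound 4 in this assay is 35 nM, expected to fall between 15 nM and 90 nM.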

Compound 4, half-maximal inhibitory concentration: 23 nM
For compound 4 the middle estimate is 1.5-fold (0.18 log units) above the measured one; low and high end bracket the measured number.
By their numbers in this assay, from the lowest: compounds 4, 3, 2 and 1 (each within the scatter of the next, the first and the last beyond it).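

In this assay, the aromatic carbon next to the ring sulfur takes either methyl or hydrogen with no readable difference: the step is a 1.1-fold lower number from compound 3 to compound 4 (0.04 log units; within the scatter), well within the scatter. Among the compounds shown here, this is the first direct reading at this position, and it shows that the 4,5-dimethyl-1,3-thiazol-2-yl group of compound 3 can give way to the 4-methyl-1,3-thiazol-2-yl group without the number moving measurably. The exchange of the whole five-membered ring now gives a step beyond the scatter, a 2.0-fold lower number from compound 1 to compound 4 (0.31 log units; beyond the scatter), though only a modest one and only just past the line, whereas the corresponding exchange leading to compound 3 stayed within it. Nothing available here accounts for either step.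

The compounds shown leave open whether this carbon tolerates anything larger than methyl, such as an ethyl chain, an amine or a carboxylic acid, since only methyl and hydrogen have been read there. They also leave open what happens when the remaining methyl on the ring is replaced by hydrogen or by a longer chain.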